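Ethyl in place of methyl on one ester of compound 3

The source may hold more compounds than are shown below. What is called first, only, known or untested is meant among the compounds shown, and "the series" means these compounds.

Compound 3 `COCCOC(=O)C1=C(C)NC(C)=C(C(=O)OC)C1c1cnc(SC)n1Nc1ccccc1` is the weakest of the three measured compounds in an assay on isolated protein (strain albino) for antagonist activity at Voltage-dependent L-type calcium channel subunit alpha-1C (Cavia porcellus) (a lower number here means a stronger inhibitor, a higher number a weaker inhibitor), where compound 3 gives 9.65 nM. Compound 1 `COC(=O)C1=C(C)NC(C)=C(C(=O)OC)C1c1cnc(SC)n1Nc1ccccc1` gives 3.54 nM in this assay, and compound 2 `CCOC(=O)C1=C(C)NC(C)=C(C(=O)OCC)C1c1cnc(SC)n1Nc1ccccc1` gives 1.69 nM. The one-place step from compound 1 to compound 3 is a 2.7-fold higher number from compound 1 to compound 3 (0.44 log units; beyond the scatter), a modest loss. Compound 1 and compound 2 differ at both ester chains, so their two values are all that can be said of that pair: compound 2 shows the lower number.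

Compound 4 `CCOC(=O)C1=C(C)NC(C)=C(C(=O)OCCOC)C1c1cnc(SC)n1Nc1ccccc1` differs from compound 3 in one place: methyl in place of hydrogen on a saturated chain carbon bound to an oxygen next to a carbonyl group. Within the data shown here, no measured pair isolates this exact change on a single ester. The two values of compound 1 and compound 2, where both esters move from methyl to ethyl, point in the direction of a lower number, and the step from compound 1 to compound 3 shows that the ester chains do shift the number beyond the scatter. Compound 4 is therefore expected to show a modestly lower number than compound 3, a step of a 1.6-fold lower number from compound 3 to compound 4 (0.21 log units; within the scatter). The estimate for compound 4 in this assay is 6 nM, with a range from 2.5 nM to 15 nM.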

Compound 4, half-maximal inhibitory concentration: 2.91 nM
Beside the measured number, compound 4's estimate is 2.1-fold (0.31 log units) above it; the range from low to high includes it.
By their numbers in this assay, from the lowest: compounds 2, 4 and 1 (each within the scatter of the next, the first and the last beyond it); then compound 3.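

Among these compounds, this is the first pair in which a single ester chain alone goes from methoxycarbonyl to ethoxycarbonyl, with the other ester held as the methoxy-bearing chain, and in this assay that one added methyl gives a 3.3-fold lower number from compound 3 to compound 4 (0.52 log units; beyond the scatter). So the methyl on this saturated chain carbon bound to an oxygen next to a carbonyl group matters in its own right, and the lower number seen with compound 2 need not rest on both esters changing together. The second step adds a new reading of the methoxy itself: placing it on the chain gives a 1.7-fold higher number from compound 2 to compound 4 (0.24 log units; within the scatter), whereas the earlier step with the other ester as methyl gives a 2.7-fold higher number from compound 1 to compound 3 (0.44 log units; beyond the scatter), so the cost of this chain beyond the scatter appears only in the pair with methyl on the other ester, and nothing available here accounts for either step.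

The compounds shown leave open whether a longer chain on this ester, such as propyl or butyl, would lower the number further or lose what the ethyl gained. They also leave open how an amine at the end of the chain, in place of the methoxy, would read in this assay.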